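Sulfonamide linker chains and a carbonyl-linked replacement

The compounds below may be only part of what the source reports. "The series", "measured", "known", "first", "only" and "open" are said of these compounds alone.

Compound 2 `CN(C)C(=O)c1cc2cnc(Nc3ccc(S(=O)(=O)NCCCCCN=C=S)cc3)nc2n1C1CCCC1` gives 56.6% in a functional assay on A549 cells (Homo sapiens) for inhibition, read by CCK-8 assay, with a stated time of 72 h, tested at 1 uM (on this read-out higher numbers stand for a stronger effect at the one concentration tested and lower numbers for a weaker effect), the second highest of the three numbers recorded. Compound 1 `CN(C)C(=O)c1cc2cnc(Nc3ccc(S(=O)(=O)NCCCN=C=S)cc3)nc2n1C1CCCC1` gives 58.9%, and the pair sit within the scatter of each other; compound 3 `CN(C)C(=O)c1cc2cnc(Nc3ccc(S(=O)(=O)NCCCCCCCN=C=S)cc3)nc2n1C1CCCC1` gives 32.6%, and the step of a number 24 percentage points lower from compound 2 to compound 3 (beyond the scatter) is beyond the scatter. The steps of a number 2.3 percentage points lower from compound 1 to compound 2 (within the scatter) and a number 26.3 percentage points lower from compound 1 to compound 3 (beyond the scatter) show the same picture: lengthening the chain at the sulfonamide nitrogen costs little at first and a modest amount when the longest chain is reached.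

Compound 4 `CN(C)C(=O)c1cc2cnc(Nc3ccc(C(=O)NCCCCN=C=S)cc3)nc2n1C1CCCC1` differs from compound 2 by a group of 10 heavy atoms (6 carbon, 2 nitrogen, 1 oxygen, 1 sulfur; no ring) in place of a group of 12 heavy atoms (6 carbon, 2 nitrogen, 2 oxygen, 2 sulfur; no ring), on an aromatic carbon. The leaving group carries two oxygen and two sulfur atoms, the entering group one of each, so the sulfonamide of the three measured compounds is gone and the chain to the isothiocyanate is shorter. Within the data shown here, none of the measured steps touches this change; they all vary the chain while keeping the sulfonamide, and the chain change alone, judged from compound 1 and compound 2, would be expected to matter little. As far as these compounds go, the new linkage is untested, so the estimate is kept wide. Compound 4 is expected at 52%, between 28% and 72%, a step of a number 4.6 percentage points lower from compound 2 to compound 4 (within the scatter) from compound 2 that is expected to stay within the scatter.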

Compound 4, a percentage reported as inhibition, at one concentration (the size of the read-out at that concentration, not a potency): 30.2%
Compound 4: the middle estimate sits 21.8 percentage points above what was measured; low and high end bracket the measured number.
By their numbers in this assay, from the lowest: compounds 4 and 3 (each within the scatter of the next); then compounds 2 and 1 (each within the scatter of the next).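

Replacing the sulfonamide-linked chain on the aromatic carbon with a carbonyl-linked one is not a neutral change in this assay: it gives a number 26.4 percentage points lower from compound 2 to compound 4 (beyond the scatter) and a number 28.7 percentage points lower from compound 1 to compound 4 (beyond the scatter), so a loss of this size no longer belongs only to the longest sulfonamide chain, seen in compound 3. The entering and leaving groups of the second step have the same heavy-atom count, so among these compounds the loss does not simply follow the size of the group, and compound 4 lies within the scatter of compound 3 even though the two carry different groups at this place. Nothing available on these compounds accounts for the loss.

Compound 4 changes the linkage and the chain together, and these compounds do not separate the two changes. A sulfonamide carrying the same chain as compound 4, and a carbonyl linkage carrying a longer chain, would divide the two. As far as these compounds go, it also remains open how far the read-out depends on the isothiocyanate, which an amine at the chain end would test on either linkage.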